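Shifting the Chlorine Around a Shared Core

The source may report more compounds than this note shows. Statements on the series, on what has been measured and on what is new or still open speak of the compounds shown alone.

Compound 3 `Oc1ccc(-c2cc(-c3ccccc3)nc(-c3ccc(Cl)cc3)c2)cc1` is one of three measured analogues built on a shared core. In a functional assay on HCT-15 cells (Homo sapiens) for cytotoxicity, read by CCK-8 assay and cell counting, with a stated time of 2 days (a lower number here means a stronger inhibitor, a higher number a weaker inhibitor), compound 3 gives 6920 nM, the second highest of the three numbers. Its nearest neighbour is compound 1 `Oc1ccc(-c2cc(-c3ccccc3)nc(-c3ccccc3Cl)c2)cc1`, which gives 4990 nM; the step of a 1.4-fold higher number from compound 1 to compound 3 (0.14 log units; within the scatter) is within the scatter, so the two cannot be ranked. For the measured compounds named here, compound 2 `Oc1ccc(-c2cc(-c3cccnc3)nc(-c3cccc(Cl)c3)c2)cc1`, which gives 21300 nM, lies furthest away, beyond the scatter, but it differs from compound 3 in two places, so no single step can be drawn from it.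

Compound 4 `Oc1ccc(-c2cc(-c3ccccc3)nc(-c3cccc(Cl)c3)c2)cc1` is the unmeasured member: 3-chlorophenyl in place of 4-chlorophenyl on an aromatic carbon. Going by the values given here, the one measured step that bears on this change, a 1.4-fold higher number from compound 1 to compound 3 (0.14 log units; within the scatter), also only relocated the chlorine on the same ring and produced no shift beyond the scatter. The same is expected here: no step beyond the scatter. Compound 4 is therefore expected to give 8000 nM, with a range from 3500 nM to 20000 nM, an expected step of a 1.2-fold higher number from compound 3 to compound 4 (0.06 log units; within the scatter).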

Compound 4, half-maximal inhibitory concentration: 6100 nM
The estimate for compound 4 lay 1.3-fold (0.12 log units) above the measured number; the range from low to high includes it.
By their numbers in this assay, from the lowest: compounds 1, 4 and 3 (each within the scatter of the next); then compound 2.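

In this assay the 3-chlorophenyl group fills the remaining chlorine placement on this ring: the change gives a 1.1-fold lower number from compound 3 to compound 4 (0.05 log units; within the scatter) and a 1.2-fold higher number from compound 1 to compound 4 (0.09 log units; within the scatter) and so the 2-chlorophenyl, 3-chlorophenyl and 4-chlorophenyl compounds cannot be told apart. The one step that clears the scatter lies elsewhere on the shared core, where phenyl in place of pyridin-3-yl gives a 3.5-fold lower number from compound 2 to compound 4 (0.54 log units; beyond the scatter) and so, though modest, offers the first sign among these compounds that a change in one place can move the number. Nothing measured here explains either result.

As far as these compounds go, whether this ring would tolerate something other than chlorine, such as a methoxy group or an amine, remains open. Also open, from the compounds shown here alone, is whether the pyridin-3-yl step would be the same with the chlorine placed elsewhere on its ring.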